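This account rests on a few compounds, and the source may have more. Where it says the series, first, only, none or still open, it means among the compounds named here.

Measured compounds:
- compound 1 `COc1cc2c(Nc3ccc(Br)c(F)c3)ncnc2c(OC)c1OC`: > 30000 nM
- compound 2 `COc1cc2c(Nc3ccc(B(O)O)cc3)ncnc2c(OC)c1OC`: 434 nM

In a functional assay on SGC-7901 cells (Homo sapiens) for antiproliferative activity, read by MTT assay, with a stated time of 72 h (a lower number here means a stronger inhibitor, a higher number a weaker inhibitor), compound 1 returns only a limit of the assay, > 30000 nM, and not a number (the limit of > 30000 nM in this assay, at which 1 of the 2 values shown sits). Compound 2 gives 434 nM in this assay. Compound 1 and compound 2 differ in more than one place, so the gap between them is noted only as what the two values show: compound 2 sits as a measured value, compound 1 at the limit.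

Compound 3 `COc1cc2c(Nc3cccc(I)c3)ncnc2c(OC)c1OC` is not yet measured. It differs from compound 1 by 3-iodophenyl in place of 4-bromo-3-fluorophenyl on a nitrogen on an aromatic ring, in words: 3-iodophenyl in place of 4-bromo-3-fluorophenyl on a nitrogen on an aromatic ring. Because compound 1 stands at > 30000 nM, the step is expected to run toward stronger inhibition, though its size is uncertain and may stay within the scatter. The expected step is an at least 3.0-fold lower number from compound 1 to compound 3 (0.47 log units; beyond the scatter). Compound 3 is estimated at 10000 nM, within 1500 nM to 30000 nM.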

Compound 3, half-maximal inhibitory concentration: 8640 nM
Compound 3: the middle estimate sits 1.2-fold (0.06 log units) above what was measured; measured number inside the range.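

On the nitrogen on an aromatic ring, 3-iodophenyl in place of 4-bromo-3-fluorophenyl gives the only one-place comparison shown in this assay, with an at least 3.4-fold lower number from compound 1 to compound 3 (0.54 log units; beyond the scatter). Compound 1 at > 30000 nM is a limit of the assay and not a number, so the upper size of this step stays unknown: the limit of > 30000 nM in this assay, at which 1 of the 3 values shown sits.
Even so, the change brings the series from the limit to a measured value, showing that the group at this position can shift the read-out beyond the scatter.

Open, going by these compounds, is whether the iodine alone carries the step, since the pair changes bromine, fluorine and iodine together. Also open, on these data alone, is how an amine or a carboxylic acid in place of the iodine would read in this assay.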